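The compounds below may be only part of what the source reports. "The series", "measured", "known", "first", "only" and "open" are said of these compounds alone.

Compound 1 `Cc1cccc(-n2cc(-c3ccccc3NS(=O)(=O)c3c[nH]c(=O)[nH]c3=O)nn2)c1` and compound 3 `Cc1cccc(-n2cc(-c3cccc(NS(=O)(=O)c4c[nH]c(=O)[nH]c4=O)c3)nn2)c1` have related cores; how the two cores differ is not broken down here. In an ADME assay on L02 cells (Homo sapiens) for cytotoxicity, read by MTT assay, with a stated time of 24 h (on this read-out higher numbers stand for lower toxicity in this test and lower numbers for higher toxicity in this test), compound 1 gives 21900 nM, and compound 3 gives 28300 nM. Compound 2 `Cc1ccc(-n2cc(-c3ccccc3NS(=O)(=O)c3c[nH]c(=O)[nH]c3=O)nn2)cc1` differs from compound 1 by one change, (4-methylphenyl in place of 3-methylphenyl on an aromatic nitrogen). In this assay compound 2 reaches only a limit, > 100000 nM. The step is an at least 4.5-fold higher number from compound 1 to compound 2 (0.65 log units; beyond the scatter), and its size is known only as a minimum because of the limit of > 100000 nM in this assay, at which 1 of the 3 values shown sits. Compound 4 `Cc1ccc(-n2cc(-c3cccc(NS(=O)(=O)c4c[nH]c(=O)[nH]c4=O)c3)nn2)cc1` differs from compound 3 by the same change, (4-methylphenyl in place of 3-methylphenyl on an aromatic nitrogen), made at the same place. Compound 4 is expected to show a 4.2-fold higher number from compound 3 to compound 4 (0.63 log units; beyond the scatter). This expectation rests on an at least 4.5-fold higher number from compound 1 to compound 2 (0.65 log units; beyond the scatter). Compound 4 is therefore estimated at 120000 nM, a value likely to be reported as a limit rather than a number.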

Compound 4, half-maximal cytotoxic concentration: 23100 nM
Compound 4: the middle estimate sits 5.2-fold (0.72 log units) above what was measured, and the stated range ends above it.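

On the core of compound 3 the change gives a 1.2-fold lower number from compound 3 to compound 4 (0.09 log units; within the scatter), so in this assay the rise seen on the core of compound 1 is not repeated: the same change on two cores in this assay, an at least 4.5-fold higher number (0.65 log units; beyond the scatter) from compound 1 to compound 2 and a 1.2-fold lower number (0.09 log units; within the scatter) from compound 3 to compound 4, at least 5.5-fold (0.74 log units) apart, beyond the scatter of two such steps Compound 2 gives > 100000 nM, which is a limit of the assay. These two pairs show that the step differs between the two cores, but they do not show which difference between the cores accounts for this, or how the change would behave on any other core.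

On these data alone, it remains open how a methoxy group, a chlorine or a carboxylic acid in place of the methyl would read on either core. As far as these compounds go, an unsubstituted phenyl on the same aromatic nitrogen also remains open.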